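A few compounds are considered here, and "the series" means these few. Any claim that something is new, unique, unknown or untested is made for them only; others in the source may bear on it.

Measured so far in a functional assay on MIA PaCa-2 cells (Homo sapiens) for inhibition, read by MTT assay, with a stated time of 7 days; a higher number here means a weaker inhibitor, a lower number a stronger inhibitor:
compound 1 `CCN(CC)S(=O)(=O)c1ccc(S(=O)(=O)N2CCC[C@@H](C(=O)N[C@H]3CC[C@H](OC)CC3)C2)cc1` gives 1350 nM
compound 2 `CCN(CC)S(=O)(=O)c1ccc(S(=O)(=O)N2CCC[C@@H](C(=O)NC3CCOCC3)C2)cc1` gives 3770 nM
compound 3 `CCN(CC)S(=O)(=O)c1ccc(S(=O)(=O)N2CCC[C@@H](C(=O)N3CCC(F)(F)CC3)C2)cc1` gives 16 nM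

Compound 1 stands second highest of these three numbers: its nearest neighbour is reached by a 2.8-fold higher number from compound 1 to compound 2 (0.45 log units; beyond the scatter), its furthest by an 84-fold lower number from compound 1 to compound 3 (1.93 log units; beyond the scatter). Compound 4 `CCN(CC)S(=O)(=O)c1ccc(S(=O)(=O)N2CCC[C@@H](C(=O)N3CCC(C(F)F)CC3)C2)cc1` differs from compound 1 in one place: 4-(difluoromethyl)piperidin-1-yl in place of (4-methoxycyclohexyl)amino on a carbonyl carbon. Going by the values given here, the closest precedent is the change to 4,4-difluoropiperidin-1-yl on the same carbonyl carbon, which gave an 84-fold lower number from compound 1 to compound 3 (1.93 log units; beyond the scatter) and a 240-fold lower number from compound 2 to compound 3 (2.37 log units; beyond the scatter), both large drops. Since 4-(difluoromethyl)piperidin-1-yl is not the same group as 4,4-difluoropiperidin-1-yl, the drop in this assay is expected to be large but is less certain in size. Compound 4 is therefore estimated at 40 nM, between 10 nM and 200 nM, an expected step of a 34-fold lower number from compound 1 to compound 4 (1.53 log units; beyond the scatter).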

Compound 4, half-maximal inhibitory concentration: 420 nM
The estimate for compound 4 lay 11-fold (1.02 log units) below the measured number, outside the stated range (above it).
By their numbers in this assay, from the lowest: compound 3; then compound 4; then compound 1; then compound 2.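

On this carbonyl carbon, a piperidin-1-yl ring does not by itself bring the large drop seen with compound 3: in this assay, 4-(difluoromethyl)piperidin-1-yl gives only modest steps (a 3.2-fold lower number from compound 1 to compound 4 (0.51 log units; beyond the scatter); a 9.0-fold lower number from compound 2 to compound 4 (0.95 log units; beyond the scatter)). The two fluorinated piperidines also stand far apart (a 26-fold higher number from compound 3 to compound 4 (1.42 log units; beyond the scatter)), so losing the amide hydrogen does not settle the outcome; which fluorinated group enters matters as well. No measurement at hand explains that gap.

Open, as far as these compounds go, is where unsubstituted piperidin-1-yl, 4-fluoropiperidin-1-yl or 4-(trifluoromethyl)piperidin-1-yl would fall relative to compound 3 and compound 4.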